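The source may hold more compounds than are shown below. What is called first, only, known or untested is meant among the compounds shown, and "the series" means these compounds.

Measured compounds:

Compound 1, `OCCNC(=S)Nc1ccccc1`, in a toxicity assay on RAW264.7 cells (Mus musculus) for cytotoxicity, read by MTT assay, with a stated time of 24 h (a higher number here means that more compound is tolerated, a lower number that less compound is tolerated), gives 105000 nM.
Compound 2, `COc1ccc(NC(=S)NCc2ccccc2)cc1`, in this assay gives 105000 nM.

Both measured compounds share a thiourea linker between two carbon-based ends, and on the numbers shown compound 2 stands level with compound 1: the two values agree at the digits given, and the small difference between them lies within the scatter that repeated measurements of this kind usually show. Neither compound can be called better tolerated than the other.

Compound 3, `CC(C)c1ccc(NC(=S)NCc2ccccc2)cc1`, has not yet been measured in this assay. Its structure differs from compound 2 in one place: isopropyl in place of methoxy on an aromatic carbon. The group that leaves carries one hydrogen-bond acceptor; the group that enters carries none.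

Among the measured compounds shown here, no measured pair here shows how such a change affects this assay. With compound 1 and compound 2 sitting at the same value despite differing ends, the expected step in this assay is none beyond the scatter, with a slight lean toward less compound being tolerated. Compound 3 is therefore expected to give about 90000 nM, with a range from 40000 nM to 200000 nM, which means an expected step of a 1.2-fold lower number from compound 2 to compound 3 (0.07 log units; within the scatter).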

Compound 3, half-maximal cytotoxic concentration: 121000 nM
For compound 3 the middle estimate is 1.3-fold (0.13 log units) below the measured one, within the range that was stated.
By their numbers in this assay, from the lowest: compounds 1, 2 and 3 (each within the scatter of the next).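

Among the compounds shown here, measured in this assay the change of methoxy to isopropyl, on an aromatic carbon para to a large group, gives a 1.2-fold higher number from compound 2 to compound 3 (0.06 log units; within the scatter) and is the first comparison here in which only one place differs. Compounds 1 and 2 differ at both ends, so their matching values could not show what any single group contributes, whereas this pair isolates one position. At this position, a group with one hydrogen-bond acceptor can give way to a slightly larger group of three carbons with no acceptor, with no change beyond the scatter; no measured property of either group is available to explain this result.

From the compounds shown here alone, one substitution cannot show how far this tolerance extends, so it remains open whether an amine, a carboxylic acid, a halogen such as chlorine or a longer carbon chain at the same position would also stay within the scatter. Going by these compounds, it also remains open whether the change from methoxy to isopropyl would have the same small effect at another place on the ring or on a different core.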